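This account rests on a few compounds, and the source may have more. Where it says the series, first, only, none or still open, it means among the compounds named here.

Working notes on the series. Among the measured compounds shown here, in an assay on HEK293 cells for agonist activity at transient receptor potential cation channel subfamily M member 8 (Homo sapiens), read by fluorescence and calcium flux, with a stated time of 15 min (a higher number here means that more compound is needed for the effect, a lower number that less compound is needed), compound 1 `Cc1ccc(OCC(=O)N(Cc2cccs2)c2nccs2)cc1` gives 2240 nM, the highest of the two numbers so far; the nearest number belongs to compound 2 `Cc1ccc2oc(C(=O)N(Cc3cccs3)c3ccn[nH]3)cc2c1`, which in this assay gives 40 nM, a gap beyond the scatter. Compound 3 `Cc1ccc(OCC(=O)N(CCCO)Cc2cccs2)cc1` is not yet measured. Relative to compound 1 it carries the change (3-hydroxypropyl in place of 1,3-thiazol-2-yl on an amide-type nitrogen). For the measured compounds named here, no measured pair shows such a change, so the step has no precedent here. The expected step from compound 1 to compound 3 is a 2.2-fold higher number from compound 1 to compound 3 (0.35 log units; beyond the scatter), a modest move toward a higher number. For compound 3 in this assay the estimate is 5000 nM, with a range from 1500 nM to 20000 nM.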

Compound 3, half-maximal effective concentration: 3000 nM
Estimate against measurement, compound 3: 1.7-fold (0.22 log units) above; the range from low to high includes it.
By their numbers in this assay, from the lowest: compound 2; then compounds 1 and 3 (each within the scatter of the next).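

In this assay, 3-hydroxypropyl in place of 1,3-thiazol-2-yl on the amide-type nitrogen is a 1.3-fold higher number from compound 1 to compound 3 (0.13 log units; within the scatter), the first step read at this position. At this place on the core of compound 1, the assay therefore does not separate a five-membered aromatic ring from a chain with no ring. Nothing measured here bears on why the two groups read alike. Open, from the compounds shown here alone, is how an amine, a carboxylic acid or a longer chain in place of 3-hydroxypropyl would read on this nitrogen. Also open, going by these compounds, is whether the same exchange reads alike on the core of compound 2.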